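Methyl in place of hydrogen: from compound 2 to compound 3

The source may hold more compounds than are shown below. What is called first, only, known or untested is meant among the compounds shown, and "the series" means these compounds.

compound 1 `C=C(CC)C(=O)c1ccc(OC(C)C(=O)O)cc1C` — > 60000 nM
compound 2 `C=C(CC)C(=O)c1ccc(OCC(=O)O)cc1Br` — > 60000 nM

In a functional assay on HL-60 cells (Homo sapiens) for antiproliferative activity, with a stated time of 72 h (on this read-out lower numbers stand for stronger inhibition of growth and higher numbers for weaker inhibition of growth), compound 2 gives > 60000 nM, which is a limit of the assay and not a number. Compound 1 likewise reaches only a limit, > 60000 nM. Compound 3 `C=C(CC)C(=O)c1ccc(OC(C)C(=O)O)cc1Br` differs from compound 2 by methyl in place of hydrogen on a saturated chain carbon bound to a carbonyl carbon and an oxygen on an aromatic ring. For the measured compounds named here, no measured step between compounds is available, and both known values stop at the same limit (the limit of > 60000 nM in this assay, at which 2 of the 2 values shown sit). The step from compound 2 to compound 3 in this assay is therefore expected to be none beyond the scatter, estimated as a step that the limit leaves unreadable from compound 2 to compound 3. Compound 3 is expected to give 80000 nM, in the range 30000 nM to 300000 nM, most likely again only as a limit.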

Compound 3, concentration for 50% growth inhibition: > 60000 nM
Compound 3 ended at the assay's limit; the forecaster's own chance of this, stated with the estimate: 85%; the middle value lies beyond the limit too.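

No step to compound 3 can be read, from compound 1 or from compound 2, because all three compounds stop at the same limit: the limit of > 60000 nM in this assay, at which 3 of the 3 values shown sit.

The compounds shown leave open whether methyl in place of hydrogen, or bromo in place of methyl, changes growth inhibition at all.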